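Chloro to Fluoro on the Benzyl Ring of Compound 1

The source may hold more compounds than are shown below. What is called first, only, known or untested is meant among the compounds shown, and "the series" means these compounds.

Three compounds have been measured in a functional assay on L1210 cells (Mus musculus) for cytotoxicity, read by cell counting, with a stated time of 2 days; a higher number here means a weaker inhibitor, a lower number a stronger inhibitor:

Compound 1 `C=C(Br)C(=O)Nc1cccc(/C=C2\SC(=O)N(Cc3cccc(Cl)c3)C2=O)c1` gives 1100 nM.
Compound 2 `Nc1ccc(/C=C2\SC(=O)N(Cc3ccccc3)C2=O)cc1` gives 38000 nM.
Compound 3 `Nc1cccc(/C=C2\SC(=O)N(Cc3cccc(Cl)c3)C2=O)c1` gives 211000 nM.

Compound 1 stands lowest of the three numbers, with compound 2 nearest and compound 3 furthest, both beyond the scatter. Among the measured compounds shown here, the only single-point step measured is a 190-fold higher number from compound 1 to compound 3 (2.28 log units; beyond the scatter), which concerns the amide nitrogen and not the benzyl ring.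

Compound 4 `C=C(Br)C(=O)Nc1cccc(/C=C2\SC(=O)N(Cc3cccc(F)c3)C2=O)c1` differs from compound 1 by fluoro in place of chloro on an aromatic carbon. For the measured compounds named here, no measured step bears on this change; the one measured step touches a different part of the molecule. For the step to compound 4 a change within the scatter is expected, a 1.4-fold higher number from compound 1 to compound 4 (0.13 log units; within the scatter). Compound 4 is therefore estimated at 1500 nM, between 600 nM and 4000 nM.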

Compound 4, half-maximal inhibitory concentration: 590 nM
Compound 4: the middle estimate sits 2.5-fold (0.41 log units) above what was measured; measured number outside the range, below it.
By their numbers in this assay, from the lowest: compounds 4 and 1 (each within the scatter of the next); then compound 2; then compound 3.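

Replacing the 3-chlorobenzyl of compound 1 with the 3-fluorobenzyl gives a 1.9-fold lower number from compound 1 to compound 4 (0.27 log units; within the scatter) in this assay. This position on the benzyl ring therefore accepts fluoro in place of chloro with no change beyond the scatter, so the two compounds cannot be ranked. The earlier compounds shown here showed a large step only at the nitrogen, and none at this ring carbon.

On these data alone, how a hydrogen, a methoxy group or a trifluoromethyl group would read at this carbon remains open. Nothing available accounts for the result.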